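The compounds below may be only part of what the source reports. "The series", "measured", "known", "first", "only" and "open" are said of these compounds alone.

Values measured in a functional assay on PANC-1 cells (Homo sapiens) for inhibition, read by MTT assay, with a stated time of 24 h; on this read-out higher numbers stand for weaker inhibition and lower numbers for stronger inhibition:

- compound 1 `CC1(C)[C@H]2CC[C@]1(C)N(Cc1cn(-c3ccc(F)cc3)nn1)C(=O)C2`: 110 nM
- compound 2 `CC1(C)[C@H]2CC[C@]1(C)N(Cc1cn(-c3ccccc3Cl)nn1)C(=O)C2`: 270 nM
- compound 3 `CC1(C)[C@H]2CC[C@]1(C)N(Cc1cn(-c3ccccc3)nn1)C(=O)C2`: 160 nM

The plain phenyl of compound 3 gives a useful reference point, since its value lies within the usual scatter of both others: a 1.5-fold higher number from compound 1 to compound 3 (0.16 log units; within the scatter), and a 1.7-fold lower number from compound 2 to compound 3 (0.23 log units; within the scatter). The next compound, compound 4 `CC1(C)[C@H]2CC[C@]1(C)N(Cc1cn(-c3ccc(Cl)cc3)nn1)C(=O)C2`, carries chloro in place of hydrogen on an aromatic carbon, turning phenyl into 4-chlorophenyl (chloro in place of hydrogen on an aromatic carbon). The new chloro sits para to a large group.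

For the measured compounds named here, no measured step makes exactly this change. The closest guide is compound 1, whose 4-fluorophenyl has a different halogen in the same place, and a 1.5-fold higher number from compound 1 to compound 3 (0.16 log units; within the scatter). Compound 2 has chloro in another place on the ring, and a 1.7-fold lower number from compound 2 to compound 3 (0.23 log units; within the scatter). Only a 2.5-fold higher number from compound 1 to compound 2 (0.39 log units; beyond the scatter) exceeds the scatter, and that modest step changes both the halogen and its place. Neither halogen step involving compound 3 leaves the scatter, so no clear shift is expected, at most a slightly lower number. The step expected is a 1.2-fold lower number from compound 3 to compound 4 (0.09 log units; within the scatter), which is estimated to stay within the scatter. Compound 4 is expected to give about 130 nM, with an estimated range from 65 nM to 260 nM.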

Compound 4, half-maximal inhibitory concentration: 440 nM
The estimate for compound 4 lay 3.4-fold (0.53 log units) below the measured number, and the stated range ends below it.
By their numbers in this assay, from the lowest: compounds 1, 3, 2 and 4 (each within the scatter of the next, the first and the last beyond it).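

In this assay, chloro on the aromatic carbon para to a large group produces the first step away from plain phenyl that leaves the scatter (a 2.8-fold higher number from compound 3 to compound 4 (0.44 log units; beyond the scatter)). The identity of the halogen matters at this place: exchanging fluoro for chloro gives the largest step among these compounds (a 4.0-fold higher number from compound 1 to compound 4 (0.60 log units; beyond the scatter)), so the small gap between the 4-fluorophenyl and plain phenyl compounds did not carry over to chloro. The position of the chloro on the ring cannot be resolved from these numbers (a 1.6-fold higher number from compound 2 to compound 4 (0.21 log units; within the scatter)), even though only compound 4, and not compound 2, lies beyond the scatter of compound 3.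

Nothing measured here gives a reason for the difference between fluoro and chloro at this place. With only fluoro and chloro in that position, the compounds shown leave open how a bromo, methyl or methoxy group would read there, and whether an amine or a carboxylic acid in the same place would shift the number in either direction.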